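The source may hold more compounds than are shown below. What is called first, only, known or untested is meant among the compounds shown, and "the series" means these compounds.

Measured so far:
- compound 1, `CC[C@@H]1C(=O)N(C)c2cnc(Nc3ccc(S(=O)(=O)NC4CCCC4)cc3)nc2N1C1CCCC1`: 1150 nM
- compound 2, `CCCCNC(=O)c1ccc2c(ccn2-c2ncc3c(n2)N(C2CCCC2)[C@H](CC)C(=O)N3C)c1`: 1160 nM

Of the compounds shown here, two have been tested in a functional assay on A549 cells (Homo sapiens) for antiproliferative activity, read by CCK-8 assay, with a stated time of 72 h; on this read-out higher numbers stand for weaker inhibition of growth and lower numbers for stronger inhibition of growth. Compound 1 `CC[C@@H]1C(=O)N(C)c2cnc(Nc3ccc(S(=O)(=O)NC4CCCC4)cc3)nc2N1C1CCCC1` gives 1150 nM, and compound 2 `CCCCNC(=O)c1ccc2c(ccn2-c2ncc3c(n2)N(C2CCCC2)[C@H](CC)C(=O)N3C)c1` gives 1160 nM; the two numbers lie within the usual scatter of each other, so neither can be set apart from the other. Compound 1 is the starting point for the next compound, compound 3 `CC[C@@H]1C(=O)N(C)c2cnc(Nc3ccc(S(=O)(=O)NCCCO)cc3)nc2N1C1CCCC1`, which is not yet measured in this assay. The change is 3-hydroxypropyl in place of cyclopentyl on a sulfonamide nitrogen. Within the data shown here, no pair of measured compounds that differ in one place is available, so the size of this kind of step is unknown here. The expectation for compound 3 is a small step, if any, from compound 1, perhaps toward a slightly higher number, of about a 1.4-fold higher number from compound 1 to compound 3 (0.14 log units; within the scatter). Compound 3 is therefore estimated at 1600 nM in this assay, within a range of 500 nM to 5000 nM.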

Compound 3, concentration for 50% growth inhibition: 437 nM
Estimate against measurement, compound 3: 3.7-fold (0.56 log units) above; measured number below the stated range.
By their numbers in this assay, from the lowest: compound 3; then compounds 1 and 2 (each within the scatter of the next).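

In this assay, among these compounds, 3-hydroxypropyl in place of cyclopentyl on the sulfonamide nitrogen gives a 2.6-fold lower number from compound 1 to compound 3 (0.42 log units; beyond the scatter) and provides the first readable single-place step in this set. The position therefore responds to the group it carries, and the five-membered carbon ring of compound 1 is not needed for growth inhibition at the level seen with compound 3. No available measurement accounts for this step.

Among the compounds shown here, the single step does not separate the loss of the ring from the arrival of the hydroxyl group, and a plain propyl chain on the same nitrogen would bear directly on that question. Going by these compounds, how far the trend extends also remains open, including whether a longer hydroxyalkyl chain, a terminal amine or a carboxylic acid would be tolerated at this position.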